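A few compounds are considered here, and "the series" means these few. Any claim that something is new, unique, unknown or untested is made for them only; others in the source may bear on it.

Measured compounds in an ADME assay on HepG2 cells (Homo sapiens) for inhibition, read by fluorescence and resazurin assay, with a stated time of 72 h; on this read-out lower numbers stand for stronger inhibition and higher numbers for weaker inhibition:

Compound 1 `NS(=O)(=O)c1ccc(Nc2ncc(Cl)c(Nc3ccc4nc[nH]c4c3)n2)cc1` gives 7800 nM.
Compound 2 `O=C(O)c1ccc(Nc2nccc(Nc3ccc4nc[nH]c4c3)n2)cc1` gives > 25000 nM, which is a limit of the assay and not a number.
Compound 3 `CS(=O)(=O)Nc1cccc(Nc2nccc(Nc3ccc4nc[nH]c4c3)n2)c1` gives > 25000 nM, which is a limit of the assay and not a number.

Compound 2 stands at the top of the numbers shown: its result is a limit, and of the three compounds only compound 1 gives a measured number. The picture is dominated by the limit of > 25000 nM in this assay, at which 2 of the 3 values shown sit, so the cell-based inhibition of compound 2 is known only to be weaker than that limit, not by how much.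

Compound 4 `Cc1ccc(Nc2nccc(Nc3ccc4nc[nH]c4c3)n2)cc1` is not yet measured. It differs from compound 2 in one place: methyl in place of carboxy on an aromatic carbon. Among the measured compounds shown here, no measured step between two compounds that differ in one place is available here, so the size of the change can only be estimated. A step toward stronger inhibition in this assay is expected, since the shared core with a different small substituent, compound 1, gives a measured number rather than a limit, though compound 1 also differs elsewhere. The expected step from compound 2 to compound 4 is an at least 1.6-fold lower number from compound 2 to compound 4 (0.22 log units; that floor lies within the scatter), and it may well remain within scatter of the limit. Compound 4 is estimated at 15000 nM, between 5000 nM and 40000 nM.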

Compound 4, half-maximal inhibitory concentration: > 25000 nM
Compound 4: a limit, no number (the forecaster's own chance of this, stated with the estimate: 40%); middle value at least 1.6-fold (0.22 log units) away from the limit.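

Compound 2 and compound 4 each give only a limit of the assay and not a number in this assay, so no step can be read between them, because both sit at the same limit: the limit of > 25000 nM in this assay, at which 3 of the 4 values shown sit. The compounds shown leave open whether methyl in place of carboxy on that aromatic carbon changes the inhibition at all.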